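Swapping an Amine Side Chain for a Hydroxyethyl Group

The compounds below may be only part of what the source reports. "The series", "measured", "known", "first", "only" and "open" are said of these compounds alone.

Of the compounds shown here, three built on one shared core have been tested in a functional assay on MDA-MB-231 cells (Homo sapiens) for inhibition, read by sulforhodamine B assay, with a stated time of 48 h; on this read-out higher numbers stand for weaker inhibition and lower numbers for stronger inhibition. Compound 1 `COc1ccc(C(c2ccccc2O)c2cccc3ccccc23)c(OC)c1OC` gives 17700 nM in this assay. Compound 2 `COc1ccc(/C(=N/OC(C)=O)c2cccc3ccccc23)c(OC)c1OC` gives 17000 nM. Compound 3 `COc1ccc(C(c2ccc(OC(C)CN(C)C)cc2)c2cccc3ccccc23)c(OC)c1OC` gives 4340 nM, the lowest of the three numbers; its gaps to compound 2 and to compound 1 both lie beyond the usual scatter of repeated measurements, so compound 3 is the strongest inhibitor among the three.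

Compound 4 `COc1ccc(C(c2ccc(OCCO)cc2)c2cccc3ccccc23)c(OC)c1OC` has not yet been measured in this assay. It differs from compound 3 in a single place: 2-hydroxyethyl in place of 1-((dimethylamino)methyl)ethyl on an oxygen on an aromatic ring. The step of a 2.3-fold higher number from compound 3 to compound 4 (0.36 log units; beyond the scatter) is expected to run toward a higher number, that is toward weaker inhibition, since compound 1 without any such side chain gives 17700 nM. The step from compound 3 to compound 4 is expected to be clearly larger than the scatter. Compound 4 is therefore estimated to give about 10000 nM, with a range from 4000 nM to 25000 nM.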

Compound 4, half-maximal inhibitory concentration: > 20000 nM
Compound 4: no number, only a limit (the forecaster's own chance of this, stated with the estimate: 10%); middle value at least 2.0-fold (0.30 log units) away from the limit.
By their numbers in this assay, from the lowest: compound 3; then compounds 2 and 1 (each within the scatter of the next). At a limit, above all of these: compound 4.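

On this oxygen on an aromatic ring, the side chain decides the result in this assay: 2-hydroxyethyl in place of 1-((dimethylamino)methyl)ethyl gives an at least 4.6-fold higher number from compound 3 to compound 4 (0.66 log units; beyond the scatter), so a chain at this place does not by itself keep the stronger inhibition of compound 3. For compound 4, the reported value is a limit of the assay, not a number: the limit of > 20000 nM in this assay, at which 1 of the 4 values shown sits. With 4-(2-hydroxyethoxy)phenyl in place of 2-hydroxyphenyl on a saturated chain carbon bound to two aromatic carbons, the data give an at least 1.1-fold higher number from compound 1 to compound 4 (0.05 log units; that floor lies within the scatter). The exact size of neither step can be fixed.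

The change removes the dimethylamino group and the branch together and adds a hydroxyl group, so the compounds shown do not tell which of these matters. An unbranched 2-(dimethylamino)ethyl chain, or a longer chain ending in a carboxylic acid, would help to separate them.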